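Swapping a Benzyl Substituent in a Receptor Agonist Series

The compounds below may be only part of what the source reports. "The series", "measured", "known", "first", "only" and "open" are said of these compounds alone.

Three measured compounds share one core and differ only in the group on a single aromatic carbon. Compound 1 `O=C(O)c1ccccc1-c1ccc(CCc2ncc(C3CCCCC3)[nH]2)cc1` gives 14.7 nM in an in vitro functional assay on cells for agonist activity at Bombesin receptor subtype-3 (Mus musculus), read by luminescence and calcium flux (a lower number here means that less compound is needed, a higher number that more compound is needed for the effect), compound 2 `O=C(O)c1ccccc1-c1ccc(CCc2ncc(CC3CCCC3)[nH]2)cc1` gives 7.9 nM, and compound 3 `COc1cccc(Cc2cnc(CCc3ccc(-c4ccccc4C(=O)O)cc3)[nH]2)c1` gives 79 nM, the highest of the three numbers. The steps of a 5.4-fold higher number from compound 1 to compound 3 (0.73 log units; beyond the scatter) and a 10-fold higher number from compound 2 to compound 3 (1.00 log units; beyond the scatter) show that the 3-methoxybenzyl group yields a higher number than either saturated ring. Compound 4 `O=C(O)c1ccccc1-c1ccc(CCc2ncc(Cc3ccccc3Cl)[nH]2)cc1` keeps a benzyl arrangement but carries 2-chlorophenyl in place of 3-methoxyphenyl on a saturated chain carbon bound to an aromatic carbon. Within the data shown here, no measured step compares one substituted phenyl with another, so the change is expected to matter little, with an expected step of a 1.3-fold lower number from compound 3 to compound 4 (0.12 log units; within the scatter) that stays within the scatter. The estimate for compound 4 is 60 nM, ranging from 15 nM to 250 nM.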

Compound 4, half-maximal effective concentration: 22 nM
Compound 4: middle estimate off by 2.7-fold (0.44 log units), on the high side; the range from low to high includes it.
By their numbers in this assay, from the lowest: compounds 2, 1 and 4 (each within the scatter of the next, the first and the last beyond it); then compound 3.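

The aromatic ring of a benzyl group does not by itself give a high number at this position: 2-chlorophenyl in place of 3-methoxyphenyl brings the value down (a 3.6-fold lower number from compound 3 to compound 4 (0.56 log units; beyond the scatter)). The 2-chlorobenzyl group stays within the scatter of cyclohexyl (a 1.5-fold higher number from compound 1 to compound 4 (0.18 log units; within the scatter)) but not of cyclopentylmethyl (a 2.8-fold higher number from compound 2 to compound 4 (0.44 log units; beyond the scatter)). The choice of substituent on that ring therefore matters in this assay.

No supporting evidence explains this difference. As far as these compounds go, how a plain benzyl or a 3-chlorobenzyl group would compare remains open, and with it whether the chlorine itself or its place on the ring matters.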